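The source may hold more compounds than are shown below. What is called first, only, known or untested is meant among the compounds shown, and "the series" means these compounds.

Compound 1 `CCc1ccccc1NS(=O)(=O)c1ccc(N2CCNC2=O)cc1` gives 180 nM
Compound 2 `O=C1NCCN1c1ccc(S(=O)(=O)Nc2ccc3[nH]ccc3c2)cc1` gives 87 nM

In a functional assay on M21 cells (Homo sapiens) for antiproliferative activity, read by sulforhodamine B assay, with a stated time of 48 h (a higher number here means a weaker inhibitor, a lower number a stronger inhibitor), compound 1 stands at 180 nM as the higher of the pair, marking it as the weaker inhibitor, and compound 2 lies at 87 nM and thus lower by a gap beyond the usual scatter. Compound 3 `Cc1cccc(NS(=O)(=O)c2ccc(N3CCNC3=O)cc2)c1` has yet to be measured. It differs from compound 1 3-methylphenyl in place of 2-ethylphenyl on a sulfonamide nitrogen by carrying 3-methylphenyl in place of 2-ethylphenyl on a sulfonamide nitrogen. Among the measured compounds shown here, no measured pair shows what such a swap does, so the size of the change remains uncertain. A move towards a higher number is expected, and the estimated 2.5-fold higher number from compound 1 to compound 3 (0.40 log units; beyond the scatter) would lie modestly beyond the scatter. In this assay compound 3 is estimated at 450 nM within an expected range (120 nM to 2000 nM).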

Compound 3, half-maximal inhibitory concentration: 69 nM
For compound 3 the middle estimate is 6.5-fold (0.81 log units) above the measured one; the measured number lies below the stated range.
By their numbers in this assay, from the lowest: compounds 3 and 2 (each within the scatter of the next); then compound 1.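

The aryl group on the sulfonamide nitrogen clearly matters in this assay: 3-methylphenyl in place of 2-ethylphenyl gives a 2.6-fold lower number from compound 1 to compound 3 (0.42 log units; beyond the scatter). Compound 3 is the stronger inhibitor of the two. Among the compounds shown here, this is the only step read at this place, and it shows that the smaller group, with 7 heavy atoms against 8, is tolerated here and does not cost activity. No measurement shown accounts for the step.

The swap alters both the chain and its place on the ring, so the compounds shown cannot separate the two, and a 2-methylphenyl or 3-ethylphenyl group on the same nitrogen would be needed to do so. As far as these compounds go, how an amine or a carboxylic acid on this ring would read in this assay also remains open.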